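Alkyl variation at the core of the amidine series

The source may hold more compounds than are shown below. What is called first, only, known or untested is meant among the compounds shown, and "the series" means these compounds.

Compound 1 `CCCCc1nc2cc(OC3CCN(C(C)=N)CC3)ccc2n1Cc1ccc2ccc(C(=N)N)cc2c1` is one of three congeners sharing a benzylated bicyclic core and a piperidinyl ether. In an assay on isolated protein for inhibition of serine protease 1 (Bos taurus) (a higher number here means a weaker inhibitor, a lower number a stronger inhibitor), compound 1 gives 14 nM, the highest of the three numbers. Compound 2 `CCCc1nc2ccc(OC3CCN(C(C)=N)CC3)cc2n1Cc1ccc2ccc(C(=N)N)cc2c1` gives 6.8 nM, and compound 3 `CCC(C)c1nc2ccc(OC3CCN(C(C)=N)CC3)cc2n1Cc1ccc2ccc(C(=N)N)cc2c1` gives 10 nM; the gap from compound 1 to compound 3 lies within the scatter, that to compound 2 just beyond it. Within the data shown here, the only step among measured compounds concerns the alkyl chain: a 1.5-fold higher number from compound 2 to compound 3 (0.17 log units; within the scatter). Compound 4 `CC(=N)N1CCC(Oc2ccc3c(c2)nc(C(C)C)n3Cc2ccc3ccc(C(=N)N)cc3c2)CC1` differs from compound 1 by isopropyl in place of butyl on an aromatic carbon. Among the measured compounds shown here, since the one alkyl change seen left this assay essentially unchanged, compound 4 is expected to stay close to compound 1, with a 1.2-fold lower number from compound 1 to compound 4 (0.07 log units; within the scatter); the estimate is 12 nM, range 5 nM to 35 nM.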

Compound 4, inhibition constant: 16 nM
Beside the measured number, compound 4's estimate is 1.3-fold (0.12 log units) below it; the range from low to high includes it.
By their numbers in this assay, from the lowest: compounds 2, 3, 1 and 4 (each within the scatter of the next, the first and the last beyond it).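

Exchanging butyl for isopropyl on this aromatic carbon gives a 1.1-fold higher number from compound 1 to compound 4 (0.06 log units; within the scatter) in this assay. The earlier step only added a methyl to a chain, whereas this one replaces the whole alkyl group with a shorter, branched one, and the number still stays within the scatter. Nothing available explains this tolerance. From the compounds shown here alone, it remains open whether the number would hold with a group other than a simple alkyl chain at this carbon, such as an amine, a carboxylic acid or a phenyl ring.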